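The compounds below may be only part of what the source reports. "The series", "measured", "known", "first", "only" and "open" are said of these compounds alone.

In an ADME assay on MT4 cells (Homo sapiens) for cytotoxicity (on this read-out lower numbers stand for higher toxicity in this test and higher numbers for lower toxicity in this test), compound 1 (`FC(F)(F)c1cccc(NC(=S)Nc2ccc(I)cc2)c1`) gives 10000 nM, compound 2 (`FC(F)(F)c1cccc(NC(=S)Nc2ccc(Cl)cc2)c1`) gives 6800 nM, and compound 3 (`C=C(C)CNC(=S)Nc1cccc(C(F)(F)F)c1`) gives 43000 nM. Compound 3 therefore holds the highest number of the three, which on this read-out means the lowest toxicity in this test. Chloro in place of iodo on an aromatic carbon gives a 1.5-fold lower number from compound 1 to compound 2 (0.17 log units; within the scatter), so the choice between these two halogens tells little here.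

Compound 4 (`Fc1cccc(NC(=S)Nc2cccc(C(F)(F)F)c2)c1`) has 3-fluorophenyl in place of 2-methylprop-2-en-1-yl on an amide-type nitrogen. The closest evidence is a similar swap seen in the opposite direction. 2-Methylprop-2-en-1-yl in place of 4-iodophenyl gives a 4.3-fold higher number from compound 1 to compound 3 (0.63 log units; beyond the scatter), and 2-methylprop-2-en-1-yl in place of 4-chlorophenyl gives a 6.3-fold higher number from compound 2 to compound 3 (0.80 log units; beyond the scatter). Read backwards, these two modest steps suggest that restoring a substituted phenyl group lowers the number. Among the measured compounds shown here, only two pairs support this reading, and neither of them carries a fluoro group, so the size remains uncertain. A step of similar size towards a lower number is expected in this assay, estimated as a 3.9-fold lower number from compound 3 to compound 4 (0.59 log units; beyond the scatter). For compound 4 the estimated value is 11000 nM, with an expected range from 5000 nM to 30000 nM.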

Compound 4, half-maximal cytotoxic concentration: 20000 nM
For compound 4 the middle estimate is 1.8-fold (0.26 log units) below the measured one; measured number inside the range.
By their numbers in this assay, from the lowest: compounds 2, 1 and 4 (each within the scatter of the next, the first and the last beyond it); then compound 3.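

Compound 4 shows that a phenyl ring on this amide-type nitrogen need not carry a heavy halogen on its 4-position for the number to sit below that of compound 3: with 3-fluorophenyl in place of 2-methylprop-2-en-1-yl there is a 2.2-fold lower number from compound 3 to compound 4 (0.33 log units; beyond the scatter), so all three phenyl-bearing compounds now lie below compound 3, and none of the compounds shown goes against this. It also shows that the choice of phenyl group can matter in this assay, since 3-fluorophenyl in place of 4-chlorophenyl gives a 2.9-fold higher number from compound 2 to compound 4 (0.47 log units; beyond the scatter), whereas 3-fluorophenyl in place of 4-iodophenyl gives a 2.0-fold higher number from compound 1 to compound 4 (0.30 log units; within the scatter), a difference that stays within the usual scatter. No measurement presented here gives a reason for any of these differences.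

From the compounds shown here alone, both phenyl swaps change the halogen and its place on the ring together, so the separate contribution of each remains unknown. A plain phenyl ring with no halogen would show what the ring alone contributes, and a saturated chain such as isobutyl would show whether the double bond of 2-methylprop-2-en-1-yl plays any part in the high number of compound 3.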